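Aryltriazole salicylanilides: a swap on the triazole aryl ring

This account rests on a few compounds, and the source may have more. Where it says the series, first, only, none or still open, it means among the compounds named here.

Measured so far:
compound 1 `COc1ccccc1-c1cn(-c2ccc(O)c(C(=O)Nc3cccc(C(F)(F)F)c3)c2)nn1` — 65%
compound 2 `COc1ccccc1-c1cn(-c2ccc(O)c(C(=O)OCCCc3ccccc3)c2)nn1` — 4%
compound 3 `COC(=O)c1cc(-n2cc(-c3ccccc3OC)nn2)ccc1O` — 6%

In a functional assay on CCRF-CEM cells (Homo sapiens) for inhibition, read by MTT assay, with a stated time of 2 days, tested at 10 uM (on this read-out higher numbers stand for more inhibition at the one concentration tested (going by the name of the read-out) and lower numbers for less inhibition), compound 1 stands highest of the three numbers: the step of a number 59 percentage points lower from compound 1 to compound 3 (beyond the scatter) and the step of a number 61 percentage points lower from compound 1 to compound 2 (beyond the scatter) are both beyond the scatter, while the step of a number 2 percentage points higher from compound 2 to compound 3 (within the scatter) is within it. Both large steps change the group on the carbonyl carbon only.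

Compound 4 `O=C(Nc1cccc(C(F)(F)F)c1)c1cc(-n2cc(-c3cccc(O)c3)nn2)ccc1O` differs from compound 1 by 3-hydroxyphenyl in place of 2-methoxyphenyl on an aromatic carbon. Going by the values given here, no measured step touches this aromatic carbon of the five-membered ring with three nitrogens, so none bears directly on the change. Since compound 4 keeps the (3-(trifluoromethyl)phenyl)amino group of compound 1, which gives 65%, compound 4 is expected to stay nearer compound 1 than compound 2 or compound 3, with wide uncertainty. The expected step is a number 10 percentage points lower from compound 1 to compound 4 (within the scatter). Compound 4 is estimated at 55%, between 25% and 80%.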

Compound 4, a percentage reported as inhibition, at one concentration (the size of the read-out at that concentration, not a potency): 13%
The estimate for compound 4 lay 42 percentage points above the measured number; the whole stated range lies above it.
By their numbers in this assay, from the lowest: compounds 2, 3 and 4 (each within the scatter of the next); then compound 1.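

In this assay, the aryl group on this aromatic carbon of the five-membered ring decides much of the read-out: with the (3-(trifluoromethyl)phenyl)amino group kept, 3-hydroxyphenyl in place of 2-methoxyphenyl gives a number 52 percentage points lower from compound 1 to compound 4 (beyond the scatter). So that amide group alone does not hold the inhibition seen with compound 1. The step joins two changes, methoxy to hydroxy and the 2- to the 3-position on the phenyl group, and nothing available explains the loss.

The compounds shown leave open which of those two changes carries the step. 2-Hydroxyphenyl and 3-methoxyphenyl would separate them, and an aminophenyl group would test another group on this carbon.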